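A few compounds are considered here, and "the series" means these few. Any claim that something is new, unique, unknown or untested is made for them only; others in the source may bear on it.

Measured compounds:
- compound 1 `COc1cccc(Oc2ccc3cc(NC(=O)c4ccc(O)c(CC=C(C)C)c4)c(=O)oc3c2C)c1`; in a functional assay on MCF7 cells (Homo sapiens) for antiproliferative activity (on this read-out lower numbers stand for stronger inhibition and higher numbers for weaker inhibition), compound 1 gives 62800 nM.
- compound 2 `COc1cccc(Oc2ccc3cc(NC(=O)c4ccc(OC)c(-c5cccc(OC)c5)c4)c(=O)oc3c2C)c1`; in this assay compound 2 gives only the assay limit > 100000 nM.
- compound 3 `COc1ccc(Nc2ccc3cc(NC(=O)c4ccc(O)c(CC=C(C)C)c4)c(=O)oc3c2C)cc1`; in this assay compound 3 gives only the assay limit > 100000 nM.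

Compound 2 thus stands at the limit, as the evidence the limit of > 100000 nM in this assay, at which 2 of the 3 values shown sit, records; no number is available for it, and only compound 1 in this set carries a numeric value.

Compound 4 `COc1ccc(Cc2ccc3cc(NC(=O)c4ccc(OC)c(-c5cccc(OC)c5)c4)c(=O)oc3c2C)cc1` is not yet measured. It differs from compound 2 by 4-methoxybenzyl in place of 3-methoxyphenoxy on an aromatic carbon, the new group sitting ortho to a methyl group, meta to a fused ring and para to a fused ring.

Going by the values given here, the one measured step at the same position, an at least 1.5-fold higher number from compound 1 to compound 3 (0.20 log units; that floor lies within the scatter), exchanges the same 3-methoxyphenoxy for an amino-linked methoxyphenyl and ends at the limit, so it says little about direction. With compound 2 already at the limit, no step beyond the scatter is expected for a step that the limit leaves unreadable from compound 2 to compound 4, and compound 4 is estimated at 150000 nM, range 50000 nM to 500000 nM, most likely again reported as a limit.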

Compound 4, half-maximal inhibitory concentration: > 100000 nM
Compound 4 gave a limit, no number; the forecaster's own chance of this, stated with the estimate: 80%; the middle value does not contradict the limit.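

In this assay compound 4 gives > 100000 nM, a limit and not a number. Going by these compounds alone, compound 2 also gives a limit, so no step between compound 2 and compound 4 can be read. The compounds shown leave open whether 4-methoxybenzyl in place of 3-methoxyphenoxy changes inhibition at all.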